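Working notes: removing the chloro group from compound 2

This account rests on a few compounds, and the source may have more. Where it says the series, first, only, none or still open, it means among the compounds named here.

Measured in a functional assay on B16-F10 cells (Mus musculus) for antiproliferative activity, read by MTT assay, with a stated time of 48 h; on this read-out higher numbers stand for weaker inhibition and lower numbers for stronger inhibition:
- compound 1 `CCCCOc1ccc(C(=O)/C=C/c2c(/C=C/c3ccc(OC)cc3)cc(OC)cc2OC)cc1`: 5.3 ug/mL
- compound 2 `COc1ccc(/C=C/c2cc(OC)cc(OC)c2/C=C/C(=O)c2ccc(Cl)cc2)cc1`: 4.9 ug/mL

Compound 2, at 4.9 ug/mL, stands within the scatter of compound 1. Next is compound 3 `COc1ccc(/C=C/c2cc(OC)cc(OC)c2/C=C/C(=O)c2ccccc2)cc1`, with hydrogen in place of chloro on an aromatic carbon, para to a large group. Going by the values given here, the only measured step bearing on this, chloro in place of butoxy, was a 1.1-fold lower number from compound 1 to compound 2 (0.03 log units; within the scatter), which lies within the scatter. No step beyond the scatter is therefore expected in this assay. The expected change is a 1.1-fold higher number from compound 2 to compound 3 (0.03 log units; within the scatter). Compound 3 is estimated at 5.2 ug/mL, with an expected range of 2.6 ug/mL to 10 ug/mL.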

Compound 3, half-maximal inhibitory concentration: 3.7 ug/mL
Beside the measured number, compound 3's estimate is 1.4-fold (0.15 log units) above it; the measured number falls inside the stated range.
By their numbers in this assay, from the lowest: compounds 3, 2 and 1 (each within the scatter of the next).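

In this assay the step to hydrogen on this aromatic carbon, para to a large group, is a 1.3-fold lower number from compound 2 to compound 3 (0.12 log units; within the scatter) and the step from the butoxy compound is a 1.4-fold lower number from compound 1 to compound 3 (0.16 log units; within the scatter) and both lie within the scatter. Earlier, only one substituent had been exchanged for another; now the substituent is gone altogether, and chloro, butoxy and hydrogen at this position still cannot be told apart on this read-out. No measured evidence bearing on this result is at hand.

Going by these compounds, whether an amine or a carboxylic acid at this carbon would give a step beyond the scatter stays open.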